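This account rests on a few compounds, and the source may have more. Where it says the series, first, only, none or still open, it means among the compounds named here.

Measured so far:
- compound 1, `COc1cc(C2CC(c3ccccc3)=NN2C(C)=O)ccc1O`: 7560 nM
- compound 2, `CC(=O)N1N=C(c2cccc3ccccc23)CC1c1ccco1`: 18000 nM
- compound 3, `O=CCN1N=C(c2ccc3ccccc3c2)CC1c1cccc(Cl)c1Cl`: 17900 nM

In a functional assay on PC-3 cells (Homo sapiens) for cytotoxicity, read by sulforhodamine B assay, with a stated time of 48 h (on this read-out higher numbers stand for weaker inhibition and lower numbers for stronger inhibition), compound 3 stands second highest of the three numbers. Its nearest neighbour is compound 2, whose number sits within the scatter of that of compound 3, so no order between these two can be read. The furthest is compound 1, whose number lies beyond the scatter below that of compound 3; these two compounds differ in several places at once, so the gap is not tied to any one change.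

The next compound, compound 4, is `COc1ccc(C2CC(c3ccc4ccccc4c3)=NN2CC=O)cc1`. It differs from compound 3 in one place: 4-methoxyphenyl in place of 2,3-dichlorophenyl on a saturated ring carbon. Among the compounds with values here, no measured pair with this same change exists, so nothing is known about the size of such a step in this assay. Within the data shown here, the only hint is compound 1, which carries a methoxy-bearing aryl and gives 7560 nM, but it also differs elsewhere, so this is weak support at best. The expectation is therefore a step of little size, possibly toward a lower number, but most likely none beyond the scatter; the estimated step of a 1.3-fold lower number from compound 3 to compound 4 (0.11 log units; within the scatter) is meant as such. For compound 4 the estimate in this assay is 14000 nM, with a range from 5000 nM to 45000 nM.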

Compound 4, half-maximal inhibitory concentration: 4530 nM
Beside the measured number, compound 4's estimate is 3.1-fold (0.49 log units) above it; the measured number lies below the stated range.
By their numbers in this assay, from the lowest: compounds 4 and 1 (each within the scatter of the next); then compounds 3 and 2 (each within the scatter of the next).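

In this assay, 4-methoxyphenyl in place of 2,3-dichlorophenyl on a saturated ring carbon gives a 4.0-fold lower number from compound 3 to compound 4 (0.60 log units; beyond the scatter). Within the data shown here, this is the first single-place step, and it lies beyond the scatter, so the number does respond to a change of the aryl group at this carbon, next to the ring nitrogen, at least with formylmethyl and the shared core held constant. The two groups match in heavy-atom count and in their six-membered aromatic ring of carbon only, so the step goes with a swap of chlorine for oxygen and with the hydrogen-bond acceptor that enters, although no measurement here gives a reason for the shift.

A single pair cannot separate the departure of the two chlorine atoms from the arrival of the methoxy group, and a plain phenyl at this carbon, or an amine or a carboxylic acid in place of the methoxy group, would be needed to tell these apart. Also open, going by these compounds, is whether the step of this size would persist with a longer chain in place of formylmethyl.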